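Swapping the Aryl Substituent on a Chalcone Boronic Ester

The source may report more compounds than this note shows. Statements on the series, on what has been measured and on what is new or still open speak of the compounds shown alone.

Compound 1 `O=C(/C=C/c1ccc2c(c1)B(O)OC2)c1ccc(I)cc1` gives, in a toxicity assay on MCF-10A cells (Homo sapiens) for cytotoxicity, read by MTT assay, with a stated time of 48 h (on this read-out higher numbers stand for weaker inhibition and lower numbers for stronger inhibition), a value that is a limit of the assay: > 100000 nM.
Compound 2 `Nc1ccc(C(=O)/C=C/c2ccc3c(c2)B(O)OC3)cc1` gives in this assay 19900 nM.

Among the measured compounds shown here, compound 2 holds the only number in this set; the other value shown, that of compound 1, is a limit and not a number. For the measured compounds named here, the one measured step runs from compound 1 to compound 2, where an at least 5.0-fold lower number from compound 1 to compound 2 (0.70 log units; beyond the scatter); it rests on (the limit of > 100000 nM in this assay, at which 1 of the 2 values shown sits), so only its smallest possible size is known.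

Compound 3 `O=C(/C=C/c1ccc2c(c1)B(O)OC2)c1cccc(F)c1` differs from compound 2 in one place: 3-fluorophenyl in place of 4-aminophenyl on a carbonyl carbon. This change removes the same amino group whose introduction marked the step from compound 1 to compound 2, and puts a halogen back on that ring, though a different one at a different position. Going by the values given here, that step is therefore the only guide, and it points toward a higher number again, of at least modest size, in this assay.

Compound 3 is accordingly expected to give about 50000 nM in this assay, within a range of 15000 nM to 150000 nM, which would mean an estimated step of a 2.5-fold higher number from compound 2 to compound 3 (0.40 log units; beyond the scatter), with a real chance that only a limit is reported.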

Compound 3, half-maximal inhibitory concentration: 15800 nM
Beside the measured number, compound 3's estimate is 3.2-fold (0.50 log units) above it, within the range that was stated.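

In this assay, a readable number does not depend on the amino group: with 3-fluorophenyl on the carbonyl carbon, the result is a 1.3-fold lower number from compound 2 to compound 3 (0.10 log units; within the scatter). A halogen on that ring therefore does not by itself return the value to a limit like that of compound 1, and compound 2 and compound 3 cannot be told apart here, even though 4-aminophenyl counts a hydrogen-bond donor and acceptor that 3-fluorophenyl does not. The 4-iodophenyl group of compound 1 now stands apart from two different replacements, the new comparison being an at least 6.3-fold lower number from compound 1 to compound 3 (0.80 log units; beyond the scatter), but this step rests on a limit and not a number, so only its smallest possible size is known: the limit of > 100000 nM in this assay, at which 1 of the 3 values shown sits.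

The 4-iodophenyl and 3-fluorophenyl groups differ both in the halogen and in where it sits, so the compounds shown do not separate these two changes. They also leave open how a methoxy group, a nitrile or a carboxylic acid on that ring would read in this assay.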